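Swapping an acetyl for ethyl on the aryl oxygen

A few compounds are considered here, and "the series" means these few. Any claim that something is new, unique, unknown or untested is made for them only; others in the source may bear on it.

Measured compounds:
Compound 1, `CCc1cccc2c(OC(C)=O)c(-c3occ(C)c3COC(C)=O)ccc12`, > 10 ug/mL
Compound 2, `CCc1cccc2c(OC)c(-c3occ(C)c3COCC(F)(F)F)ccc12`, 5.3 ug/mL

In a functional assay on MDA-MB-231 cells (Homo sapiens) for cytotoxicity, read by MTT assay, with a stated time of 72 h (on this read-out higher numbers stand for an effect only at larger amounts of compound and lower numbers for an effect already at smaller amounts), compound 1 gives only a limit, > 10 ug/mL, and not a number. Compound 1 therefore sits at the limit of > 10 ug/mL in this assay, at which 1 of the 2 values shown sits. Compound 2, measured in the same assay, gives 5.3 ug/mL. Going by the values given here, compound 2 differs from compound 1 in more than one place, so the two values only show where each stands, and no single step between them can be read.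

Compound 3, `CCOc1c(-c2occ(C)c2COC(C)=O)ccc2c(CC)cccc12`, has not yet been measured. It differs from compound 1 in one place: ethyl in place of acetyl on an oxygen on an aromatic ring. Among the compounds with values here, no step between measured compounds of this kind is known, so the size and direction of the change from compound 1 to compound 3 cannot be taken from the data. The estimate for compound 3 is therefore placed near compound 1, with a wide range: 9 ug/mL, between 3 ug/mL and 25 ug/mL, which corresponds to an expected step of an at least 1.1-fold lower number from compound 1 to compound 3 (0.04 log units; that floor lies within the scatter).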

Compound 3, concentration for half-maximal effect: 4.9 ug/mL
Estimate against measurement, compound 3: 1.8-fold (0.26 log units) above; measured number inside the range.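

Ethyl in place of acetyl on the oxygen on the aromatic ring gives the first readable step for this place in this assay: an at least 2.0-fold lower number from compound 1 to compound 3 (0.30 log units; that floor lies within the scatter). Going by these compounds, compound 1 enters this step only as a limit, so the step is a floor and its full size stays unknown: the limit of > 10 ug/mL in this assay, at which 1 of the 3 values shown sits. Compound 3 does give a number where compound 1 gives only a limit, so with ethoxy in place of acetoxy on the same core, an effect can be read in this cell assay.

Going by these compounds alone, no step involving compound 2 can be read, since it differs from each of the other two compounds in more than one place. On these data alone, how a free hydroxyl, a longer chain such as butyl, or a chain ending in an amine on this oxygen would compare with ethyl remains open.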